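The source may hold more compounds than are shown below. What is called first, only, known or untested is meant among the compounds shown, and "the series" means these compounds.

Measured so far in a functional assay on HepG2 cells (Homo sapiens) for inhibition, read by MTT assay; on this read-out lower numbers stand for stronger inhibition of growth and higher numbers for weaker inhibition of growth
- compound 1 `COc1ccc(C(=O)Nc2cccc(-c3cc(=O)c4c(OC)c(OC)c(OC)cc4o3)c2)cc1` gives 22200 nM
- compound 2 `COc1cc2oc(-c3cccc(NC(=O)c4cccc(Br)c4)c3)cc(=O)c2c(O)c1OC` gives 44800 nM

Among the compounds with values here, compound 2 stands level with compound 1, the only other measured member of the series. Their two values lie within the scatter of each other, so the pair cannot be ranked. The next compound, compound 3 `COc1ccc(C(=O)Nc2cccc(-c3cc(=O)c4c(O)c(OC)c(OC)cc4o3)c2)cc1`, has not yet been measured. It differs from compound 2 as follows: 4-methoxyphenyl in place of 3-bromophenyl on a carbonyl carbon. In words, 4-methoxyphenyl replaces 3-bromophenyl on a carbonyl carbon. Within the data shown here, no pair of measured compounds differs in one place only, so the data offer no direct guide to this change. Among the measured compounds shown here, the only evidence is the narrow spread of the two values, with compound 2 at 44800 nM and compound 1 at 22200 nM as the basis for the expectation. No step beyond the scatter is therefore expected in this assay, and the estimated change is a 1.4-fold lower number from compound 2 to compound 3 (0.15 log units; within the scatter), with no firm direction. For compound 3 the estimated value is 32000 nM, with 13000 nM to 75000 nM as the expected range.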

Compound 3, concentration for 50% growth inhibition: > 100000 nM
Compound 3 gave a limit, no number; the forecaster's own chance of this, stated with the estimate: 10%; middle value at least 3.1-fold (0.49 log units) away from the limit.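

In this assay compound 3 gives > 100000 nM, which is a limit of the assay and not a number. The earlier pair differed in more than one place and stood within the scatter, whereas two single changes now each carry a step beyond it: 4-methoxyphenyl in place of 3-bromophenyl on a carbonyl carbon gives an at least 2.2-fold higher number from compound 2 to compound 3 (0.34 log units; beyond the scatter), and hydrogen in place of methyl on an oxygen on an aromatic ring gives an at least 4.5-fold higher number from compound 1 to compound 3 (0.65 log units; beyond the scatter). Both the aryl group on the carbonyl carbon and the group on that oxygen therefore bear on growth inhibition in this series, and both steps are lower bounds whose full size cannot be read: the limit of > 100000 nM in this assay, at which 1 of the 3 values shown sits.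

The compounds shown leave open how large either step really is, and whether the aryl change would give a similar step with methyl on that oxygen, since each change is seen only in the direction that ends at the limit. They also leave open how an amine or a carboxylic acid would fare in place of the bromine or methoxy group on the aryl ring.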